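The source may hold more compounds than are shown below. What is called first, only, known or untested is meant among the compounds shown, and "the series" means these compounds.

Measured so far:
compound 1 `Clc1ccc(-c2c[se]nn2)cc1` — 57100 nM
compound 2 `C/C(=N\NC(=O)COc1cccc2cccnc12)c1ccc(Cl)cc1` — > 100000 nM
compound 3 `Brc1ccc(-c2c[se]nn2)cc1` — "not determined" (no result reported)

In an ADME assay on MCF7 cells (Homo sapiens) for cytotoxicity, read by MTT assay, with a stated time of 48 h (a lower number here means a stronger inhibitor, a higher number a weaker inhibitor), compound 1 gives 57100 nM. Compound 2 gives no number in this assay, only the limit > 100000 nM. Among the values shown compound 2 thus sits at the limit itself (the limit of > 100000 nM in this assay, at which 1 of the 3 values shown sits), and one further entry, compound 3, carries no number at all. Compound 4 `C/C(=N\NC(=O)COc1cccc2cccnc12)c1ccc(Br)cc1` is still to be measured in this assay. It differs from compound 2 by bromo in place of chloro on an aromatic carbon. Among the compounds with values here, no step between measured compounds is available for this assay; bromo in place of chloro on an aromatic carbon is expected to shift the reading little, if at all beyond the scatter. For compound 4 the expected value is 120000 nM, within 50000 nM to 300000 nM. The expected step is a step that the limit leaves unreadable from compound 2 to compound 4, with the result most likely again reported only as a limit.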

Compound 4, half-maximal inhibitory concentration: > 100000 nM
Compound 4 ended at the assay's limit; the forecaster's own chance of this, stated with the estimate: 70%; the middle value lies beyond the limit too.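

Within the data shown here, compound 2 and compound 4 both read only as limits in this assay, so no step between them can be read. The compounds shown leave open whether bromo in place of chloro changes the reading at all.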